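Swapping a nitrophenyl for a cyclohexyl on one core

The source may hold more compounds than are shown below. What is called first, only, known or untested is meant among the compounds shown, and "the series" means these compounds.

Compound 1, `Cc1cccc(Cn2c(CN3CCN(C(=O)c4ccc([N+](=O)[O-])cc4)CC3)nc3ccccc32)c1`, gives 24.3% in an assay on isolated protein for inhibition of aldehyde dehydrogenase 1A1 (Homo sapiens), read by spectrophotometry, tested at 10 uM; on this read-out higher numbers stand for more inhibition at the one concentration tested (going by the name of the read-out) and lower numbers for less inhibition.
Compound 2, `CC(C)CCn1c(CN2CCN(C(=O)c3ccco3)CC2)nc2ccccc21`, gives 42.1% in this assay.
Compound 3, `Cc1cccc(Cn2c(OC3CCN(C(=O)C4CC4)CC3)nc3ccccc32)c1`, gives 80.6% in this assay.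

Among these three numbers compound 1 stands lowest. Compound 2 sits higher by more than the usual scatter, and compound 3 sits higher still, well beyond it. Compound 4, `Cc1cccc(Cn2c(CN3CCN(C(=O)C4CCCCC4)CC3)nc3ccccc32)c1`, differs from compound 1 in a single place: cyclohexyl in place of 4-nitrophenyl on a carbonyl carbon. Going by the values given here, no measured pair shows this same change, so the size of the step is uncertain; a moderate rise in this assay is expected rather than none, since compound 3 with a small saturated ring on its carbonyl gives 80.6%. Compound 4 is therefore estimated at 45%, with a range from 20% to 70%, an expected step of a number 20.7 percentage points higher from compound 1 to compound 4 (beyond the scatter).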

Compound 4, a percentage reported as inhibition, at one concentration (the size of the read-out at that concentration, not a potency): 31.9%
For compound 4 the middle estimate is 13.1 percentage points above the measured one; measured number inside the range.
By their numbers in this assay, from the lowest: compounds 1 and 4 (each within the scatter of the next); then compound 2; then compound 3.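

On this carbonyl carbon, cyclohexyl in place of 4-nitrophenyl gives a number 7.6 percentage points higher from compound 1 to compound 4 (within the scatter) in this assay. Exchanging an aromatic six-membered ring for a non-aromatic one, and leaving out the group's hydrogen-bond acceptors, therefore makes no difference that this read-out can separate. No measurement at hand offers an explanation for this result.

The two groups compared here say little about other kinds of group at this place. From the compounds shown here alone, whether a longer chain ending in an amine on the same carbonyl carbon would shift the number remains open.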